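Methyl for Methoxy Across Two Related Cores

The source may report more compounds than this note shows. Statements on the series, on what has been measured and on what is new or still open speak of the compounds shown alone.

Compound 1 `COc1ccc(-c2nnc(COc3ccc(C#N)c(F)c3)o2)cc1` and compound 2 `Cc1ccc(-c2nnc(COc3ccc(C#N)c(F)c3)o2)cc1` differ in one place: methyl in place of methoxy on an aromatic carbon. In a functional assay on MCF7 cells (Homo sapiens) for cytotoxicity, read by MTT assay, with a stated time of 48 h (a lower number here means a stronger inhibitor, a higher number a weaker inhibitor), compound 1 gives 42200 nM. Compound 2 reaches only a limit of this assay, > 50000 nM, and not a number. The step is an at least 1.1-fold higher number from compound 1 to compound 2 (0.07 log units; that floor lies within the scatter), a floor set by the limit of > 50000 nM in this assay, at which 1 of the 3 values shown sits. Compound 3 `COc1ccc(-c2nnc(COc3ccc(-c4nnco4)cc3)o2)cc1` gives 31200 nM in this assay; the difference between the core of compound 3 and that of compound 1 is not broken down here. Compound 4 `Cc1ccc(-c2nnc(COc3ccc(-c4nnco4)cc3)o2)cc1` stands to compound 3 as compound 2 stands to compound 1: methyl in place of methoxy on an aromatic carbon, the same change at the same place. Beside the earlier step, a step of a 1.4-fold higher number from compound 3 to compound 4 (0.16 log units; within the scatter) in this assay is expected, because compound 2 sits at the limit of > 50000 nM in this assay, at which 1 of the 3 values shown sits. Compound 4 is estimated at 45000 nM in this assay, between 22000 nM and 100000 nM, with a fair chance that only a limit is returned.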

Compound 4, half-maximal inhibitory concentration: > 50000 nM
Compound 4: only a limit was reported; the forecaster's own chance of this, stated with the estimate: 45%; at least 1.1-fold (0.04 log units) between middle value and limit.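

Compound 4 returns only a limit in this assay, > 50000 nM. Methyl in place of methoxy gives an at least 1.6-fold higher number from compound 3 to compound 4 (0.20 log units; that floor lies within the scatter), and the steps on the two cores can be set side by side only as floors: the same change on two cores in this assay, an at least 1.1-fold higher number (0.07 log units; that floor lies within the scatter) from compound 1 to compound 2 and an at least 1.6-fold higher number (0.20 log units; that floor lies within the scatter) from compound 3 to compound 4; the limit leaves it open whether they differ The change thus ends at the same limit on both cores, but this does not show whether it has the same size on each, since the readings stop there: the limit of > 50000 nM in this assay, at which 2 of the 4 values shown sit.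

The compounds shown leave open how an ethoxy group, a chlorine atom or an amine at this place would read in this assay. They also leave open whether any of these groups would return a number rather than a limit on either core.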